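Shared core series: the methyl to trifluoromethyl step

The compounds below may be only part of what the source reports. "The series", "measured", "known", "first", "only" and "open" are said of these compounds alone.

Compound 1 `COc1ccc(-c2cn(Cc3ccccc3)nn2)cc1` gives 83800 nM in a functional assay on P388 cells (Mus musculus) for antiproliferative activity, read by MTT assay, with a stated time of 72 h (a lower number here means a stronger inhibitor, a higher number a weaker inhibitor), and compound 2 `Cc1ccc(-c2cn(Cc3ccccc3)nn2)cc1` gives 94100 nM. Among the compounds with values here, the only step so far, a 1.1-fold higher number from compound 1 to compound 2 (0.05 log units; within the scatter), lies within the scatter, so compound 2 stands level with compound 1 on these two numbers. Compound 3 `FC(F)(F)c1ccc(-c2cn(Cc3ccccc3)nn2)cc1` carries trifluoromethyl in place of methyl on an aromatic carbon, on an aromatic carbon of a six-membered aromatic ring of carbon only, para to a large group. Within the data shown here, no measured step bears directly on this change; the one step available, methoxy to methyl, moved nothing beyond the scatter. For compound 3 the expected step is therefore a 1.0-fold lower number from compound 2 to compound 3 (0.02 log units; within the scatter), nothing beyond the scatter. Compound 3 is estimated at 90000 nM, within 30000 nM to 250000 nM.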

Compound 3, half-maximal inhibitory concentration: 17500 nM
Estimate against measurement, compound 3: 5.1-fold (0.71 log units) above; measured number below the stated range.
By their numbers in this assay, from the lowest: compound 3; then compounds 1 and 2 (each within the scatter of the next).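

At this position, on an aromatic carbon of the ring para to a large group, the choice of group does register in this assay: trifluoromethyl in place of methyl gives a 5.4-fold lower number from compound 2 to compound 3 (0.73 log units; beyond the scatter) and trifluoromethyl in place of methoxy gives a 4.8-fold lower number from compound 1 to compound 3 (0.68 log units; beyond the scatter) at the same carbon. The methoxy to methyl step had shown no separation, so among these three groups only trifluoromethyl stands apart. Nothing at hand accounts for this shift. As far as these compounds go, whether a chlorine, a nitrile or an amine on this carbon would give a similar number remains open. So does whether the trifluoromethyl step holds with other changes elsewhere on the shared core.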